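The source may report more compounds than this note shows. Statements on the series, on what has been measured and on what is new or still open speak of the compounds shown alone.

Working notes on the series

Of the compounds shown here, three of this shared core have been measured in an assay on isolated protein for inhibition of protein kinase C iota type (Homo sapiens), tested at 20 uM; a higher number here means more inhibition at the concentration tested (going by the name of the read-out), a lower number less inhibition. Compound 1 `CC(C)(C)C1=NN(c2ccc(F)c(Cl)c2)C(c2ccc(O)cc2)C1` gives 31.6%, and compound 2 `Oc1ccc(C2CC(c3ccccc3)=NN2c2ccc(Cl)cc2)cc1` gives 31.6%; these two values lie within the scatter of each other. Compound 3 `Oc1ccc(C2CC(c3cccs3)=NN2c2ccc(Br)cc2)cc1` gives 21.4%, the lowest of the three numbers; its nearest neighbour is compound 1, and its furthest is compound 2, both higher by an amount beyond the scatter, so compound 3 stands clearly below the other two.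

The next compound, compound 4 `Oc1ccc(C2CC(c3cccs3)=NN2c2ccc(C(F)(F)F)cc2)cc1`, has not yet been measured. It differs from compound 3 in one place: trifluoromethyl in place of bromo on an aromatic carbon. Among the compounds with values here, no pair of measured compounds shows this change on its own, so the expectation rests on compound 3 alone and on the narrow spread of the series. The step from compound 3 to compound 4 is expected to be a number 3.6 percentage points higher from compound 3 to compound 4 (within the scatter), that is, no change beyond the usual scatter in either direction. In this assay compound 4 is expected to give 25%, with a range from 10% to 42%.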

Compound 4, a percentage reported as inhibition, at one concentration (the size of the read-out at that concentration, not a potency): 45.9%
For compound 4 the middle estimate is 20.9 percentage points below the measured one; measured number outside the range, above it.
By their numbers in this assay, from the lowest: compound 3; then compounds 1 and 2 (each within the scatter of the next); then compound 4.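

Trifluoromethyl in place of bromo, on an aromatic carbon para to a large group, gives a number 24.5 percentage points higher from compound 3 to compound 4 (beyond the scatter) in this assay and is the first single-place step in the series. It shows that this position is not indifferent to the group it carries: replacing this one group, with 4 heavy atoms entering where 1 leaves, is enough to move the read-out beyond the scatter. No measurement at hand bears on what lies behind this step.

Within the data shown here, whether the same change gives a similar step with the other groups of compound 1 or compound 2 in place stays open, since the series holds only this one matched pair. From the compounds shown here alone, how a methoxy group, a nitrile or an amine at this same position would read in this assay also stays open.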